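Dichloroacetanilides: methoxy to trifluoromethoxy on the aromatic ring

A few compounds are considered here, and "the series" means these few. Any claim that something is new, unique, unknown or untested is made for them only; others in the source may bear on it.

Measured so far:
compound 1 `N#Cc1cccc(NC(=O)C(Cl)Cl)c1` 66500 nM
compound 2 `COc1cccc(NC(=O)C(Cl)Cl)c1` 25800 nM

In a functional assay on A549 cells (Homo sapiens) for antiproliferative activity, read by MTT assay, with a stated time of 72 h (a higher number here means a weaker inhibitor, a lower number a stronger inhibitor), compound 2 gives the lowest of the two numbers; its nearest neighbour is compound 1, and the step of a 2.6-fold lower number from compound 1 to compound 2 (0.41 log units; beyond the scatter). Compound 3 `O=C(Nc1cccc(OC(F)(F)F)c1)C(Cl)Cl` differs from compound 2 by trifluoromethyl in place of methyl on an oxygen on an aromatic ring. For the measured compounds named here, no measured step covers this change; the only step known, from cyano to methoxy, concerns a different position of the substituent and gives no direction for it. A step of no more than modest size is therefore expected, a 1.3-fold lower number from compound 2 to compound 3 (0.11 log units; within the scatter). Compound 3 is estimated at 20000 nM, within 7000 nM to 60000 nM.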

Compound 3, half-maximal inhibitory concentration: 15100 nM
Compound 3: the middle estimate sits 1.3-fold (0.12 log units) above what was measured; low and high end bracket the measured number.
By their numbers in this assay, from the lowest: compounds 3 and 2 (each within the scatter of the next); then compound 1.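

In this assay trifluoromethyl in place of methyl on the oxygen gives a 1.7-fold lower number from compound 2 to compound 3 (0.23 log units; within the scatter) and so does not separate these two oxygen-linked groups. Trifluoromethoxy in place of cyano on the aromatic carbon gives a 4.4-fold lower number from compound 1 to compound 3 (0.64 log units; beyond the scatter) and thus, like methoxy, stands apart from cyano. No measurement available here explains either step.

As far as these compounds go, whether an amine, a carboxylic acid or a longer alkoxy chain at this aromatic carbon would move the number beyond the scatter remains open. So does whether these steps hold on any other core.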